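A few compounds are considered here, and "the series" means these few. Any claim that something is new, unique, unknown or untested is made for them only; others in the source may bear on it.

Compound 1 `O=C1Nc2ccc(Cl)cc2/C1=C/c1cccc(OCc2cn(Cc3ccccc3)nn2)c1` carries no number of its own in a functional assay on MDA-MB-231 cells (Homo sapiens) for inhibition, read by MTT assay, with a stated time of 48 h; a lower number here means a stronger inhibitor, a higher number a weaker inhibitor; the entry for compound 1 reads "not determined" (no result reported). Compound 2 `O=C1Nc2cc(Cl)ccc2/C1=C\c1cccc(OCc2cn(Cc3ccccc3)nn2)c1` returns only a limit in this assay, > 50000 nM for compound 2. Compound 3 `O=C1Nc2ccc([N+](=O)[O-])cc2/C1=C\c1cccc(OCc2cn(Cc3ccccc3)nn2)c1` likewise returns a limit in this assay, > 50000 nM for compound 3. So compound 1 stands without a measured value, and the two values that exist around it are limits rather than numbers, (the limit of > 50000 nM in this assay, at which 2 of the 3 values shown sit). Compound 4 `CC(=O)c1ccc2c(c1)/C(=C/c1cccc(OCc3cn(Cc4ccccc4)nn3)c1)C(=O)N2` differs from compound 1 by acetyl in place of chloro on an aromatic carbon. Within the data shown here, no measured step exists for this change, so no shift beyond the usual scatter is expected in this assay in either direction. Compound 4 is expected at about 50000 nM, within 15000 nM to 150000 nM, quite possibly reported again only as a limit.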

Compound 4, half-maximal inhibitory concentration: > 50000 nM
Compound 4: a limit, no number; the forecaster's own chance of this, stated with the estimate: 65%; the middle value sits exactly at the limit.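

In this assay, among these compounds, compound 4 returns only a limit, > 50000 nM, so no step between compound 1 and compound 4 can be read. Still open is whether any substituent on the shared core gives a measurable value: the limit of > 50000 nM in this assay, at which 3 of the 4 values shown sit.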